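Changing the aryl group on a sulfonamide for serotonin receptor binding

The source may hold more compounds than are shown below. What is called first, only, known or untested is meant among the compounds shown, and "the series" means these compounds.

Measured compounds:
Compound 1, `O=S(=O)(Nc1ccc2nccc(N3CCNCC3)c2c1)c1cc(Cl)cc(Cl)c1`: 25.1 nM
Compound 2, `O=S(=O)(Nc1ccc2nccc(N3CCNCC3)c2c1)c1ccc(I)cc1`: 1.59 nM

In an assay on isolated protein for binding affinity to 5-hydroxytryptamine receptor 6 (Homo sapiens) (on this read-out lower numbers stand for stronger inhibition and higher numbers for weaker inhibition), compound 1 gives 25.1 nM and compound 2 gives 1.59 nM. Compound 2 therefore stands lowest of the two numbers, with compound 1 as its nearest neighbour (a 16-fold lower number from compound 1 to compound 2 (1.20 log units; beyond the scatter)). The two share a core and differ only in the ring carried on the sulfonyl sulfur.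

For the measured compounds named here, compound 3, `Cc1cc(S(=O)(=O)Nc2ccc3nccc(N4CCNCC4)c3c2)c(C)cc1Cl`, keeps the shared core and again alters only that ring: 4-chloro-2,5-dimethylphenyl in place of 4-iodophenyl on a sulfonyl sulfur. Going by the values given here, the single measured step that bears on this change is a 16-fold lower number from compound 1 to compound 2 (1.20 log units; beyond the scatter), which shows that the pattern of substituents on this ring can move the number a great deal. Among the compounds with values here, compound 3 keeps a halogen in the 4-position of the ring, as in compound 2, but adds two methyl groups, for which no measured step exists. The expectation is a modest rise in this assay, described by a 3.1-fold higher number from compound 2 to compound 3 (0.50 log units; beyond the scatter). Compound 3 is therefore estimated at 5 nM, within a range of 1.5 nM to 20 nM.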

Compound 3, inhibition constant: 1.26 nM
Compound 3: the middle estimate sits 4.0-fold (0.60 log units) above what was measured; measured number outside the range, below it.
By their numbers in this assay, from the lowest: compounds 3 and 2 (each within the scatter of the next); then compound 1.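

In this assay the move from 4-iodophenyl to 4-chloro-2,5-dimethylphenyl on the sulfonyl sulfur gives a 1.3-fold lower number from compound 2 to compound 3 (0.10 log units; within the scatter) and so leaves the two compounds indistinguishable, even though the halogen changes and two methyl groups enter. The other comparison gives a 20-fold lower number from compound 1 to compound 3 (1.30 log units; beyond the scatter) and shows that the low number of compound 2 is not unique to a single ring: among these three compounds, both rings with a halogen in the 4-position sit well under the 3,5-dichlorophenyl ring, with no compound here going against that. Nothing available here explains why these rings compare as they do.

The compounds shown leave open what the two methyl groups and the halogen each contribute on their own, since the two changes arrive together in compound 3; a plain 4-chlorophenyl or a 4-methoxyphenyl on the same sulfur would begin to separate them. They also leave open whether an aromatic ring is needed at this position at all, a question that a simple butyl chain on the sulfonyl sulfur could address.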